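The source may report more compounds than this note shows. Statements on the series, on what has been measured and on what is new or still open speak of the compounds shown alone.

Measured compounds in a physicochemical assay for lipophilicity, using the shake flask method, in phosphate buffer, measured as octanol-water partition, with a stated time of 30 min, at pH 7.4; on this read-out lower numbers stand for lower lipophilicity and higher numbers for higher lipophilicity:
compound 1 `O=C1CCCN1c1cnc(NCc2c(F)ccc3c2CCO3)c2cn[nH]c(=O)c12` — 1.8
compound 2 `Fc1ccc2c(c1CNc1ncc(Oc3ccccc3)c3nncn13)CCO2` — 3.5
compound 3 `Cn1nccc1-c1cnc(NCc2c(F)ccc3c2CCO3)c2cn[nH]c(=O)c12` — 2.6

Compound 2 stands highest of the three numbers in this assay; compound 3 is nearest to it and compound 1 furthest, and both gaps lie beyond the scatter. Compound 4 `CN(c1cccnc1)c1cnc(NCc2c(F)ccc3c2CCO3)n2cnnc12` is the next compound to be measured. It differs from compound 2 in one place: methyl(pyridin-3-yl)amino in place of phenoxy on an aromatic carbon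

For the measured compounds named here, the only step measured within the set is a number 0.80 log units higher from compound 1 to compound 3 (beyond the scatter), a modest rise, and it concerns a different change on a different core, so it does not bear directly on the step from compound 2 to compound 4. What remains is the change itself: phenoxy leaves and methyl(pyridin-3-yl)amino enters, with one more heavy atom, one more hydrogen-bond acceptor and a six-membered aromatic ring carrying one hetero atom in place of one of carbon only. On that basis a downward step in this assay from compound 2 is expected, of a size clearly beyond the scatter, with the uncertainty mainly in its extent. Compound 4 is therefore estimated at 2.4, with a range of 1.8 to 3. The expected step is a number 1.10 log units lower from compound 2 to compound 4 (beyond the scatter).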

Compound 4, distribution coefficient: 2.6
Estimate against measurement, compound 4: 0.20 log units below, and the stated range covers the measured number.
By their numbers in this assay, from the lowest: compound 1; then compounds 3 and 4 (each within the scatter of the next); then compound 2.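

In this assay, methyl(pyridin-3-yl)amino in place of phenoxy gives a number 0.90 log units lower from compound 2 to compound 4 (beyond the scatter). For the compounds shown here, this is the first reading at this position, an aromatic carbon para to a large group on the core of compound 2, and it shows that the number moves beyond the scatter when the entering group has one more heavy atom and one more hydrogen-bond acceptor, and a ring with one hetero atom, while neither group has a hydrogen-bond donor or a net charge. Going by these compounds alone, the one earlier step, a number 0.80 log units higher from compound 1 to compound 3 (beyond the scatter), involves another pair of groups on another core, so it says nothing about this position, and nothing available explains the step measured here.

The exchange alters the atom attached to the core, adds a methyl group and changes the ring all at once, so the compounds shown cannot assign the step to any one of these; pyridin-3-yloxy and methyl(phenyl)amino at the same carbon would separate them. As far as these compounds go, whether the step holds for a smaller group at this position, such as a simple amine, or on the core of compound 1 also remains open.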